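Working notes: methylsulfanyl for trifluoromethoxy in the series

The compounds below may be only part of what the source reports. "The series", "measured", "known", "first", "only" and "open" are said of these compounds alone.

- compound 1 `O=C(CCc1cccc2c1B(O)OC2)Nc1cccc(-c2cccc(Cl)c2)c1` gives 250 nM
- compound 2 `O=C(CCc1cccc2c1B(O)OC2)Nc1cccc(-c2ccc(OC(F)(F)F)cc2)c1` gives 640 nM

Going by the values given here, both numbers come from a functional assay on MDA-MB-231 cells (Homo sapiens) for antiproliferative activity, read by MTT assay, with a stated time of 72 h (on this read-out higher numbers stand for weaker inhibition and lower numbers for stronger inhibition), and are the only measurements so far. Compound 2 holds the higher of the two numbers, and its gap to compound 1 lies beyond the scatter.

Compound 3 `CSc1ccc(-c2cccc(NC(=O)CCc3cccc4c3B(O)OC4)c2)cc1` is not yet measured. It differs from compound 2 in one place, with methylsulfanyl in place of trifluoromethoxy on an aromatic carbon and the rest of the structure unchanged. Among the compounds with values here, no measured pair differs in one place, so no direct precedent exists for this exchange. Within the data shown here, the two values, compound 1 at 250 nM and compound 2 at 640 nM, show only that numbers in this small set can differ beyond the scatter. The expected change in this assay is small and toward stronger inhibition, estimated as a 1.6-fold lower number from compound 2 to compound 3 (0.20 log units; within the scatter) and not beyond the scatter. The estimated value for compound 3 is 400 nM (expected range 130 nM to 1100 nM).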

Compound 3, half-maximal inhibitory concentration: 140 nM
The estimate for compound 3 lay 2.9-fold (0.46 log units) above the measured number; the range from low to high includes it.
By their numbers in this assay, from the lowest: compounds 3 and 1 (each within the scatter of the next); then compound 2.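

In this assay, methylsulfanyl in place of trifluoromethoxy on an aromatic carbon, para to a large group, gives a 4.6-fold lower number from compound 2 to compound 3 (0.66 log units; beyond the scatter). Going by these compounds alone, this is the first exchange that can be read at a single place, and it shows that this position on the six-membered aromatic ring of carbon only can move the number beyond the scatter with the rest of the structure unchanged. Exchange of the whole aryl group, 4-(methylsulfanyl)phenyl in place of 3-chlorophenyl on an aromatic carbon, gives a 1.8-fold lower number from compound 1 to compound 3 (0.25 log units; within the scatter), so compound 3 and compound 1 cannot be told apart in this assay.

No accompanying measurement bears on what lies behind the step from trifluoromethoxy to methylsulfanyl. Still open, from the compounds shown here alone, is whether the step belongs to the sulfur atom or to the exchange more generally: methoxy, methylsulfonyl or dimethylamino at the same place on the otherwise unchanged structure of compound 3 would separate these readings.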